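The source may report more compounds than this note shows. Statements on the series, on what has been measured and on what is new or still open speak of the compounds shown alone.

Three compounds share one core and differ only in the aromatic group attached to a saturated ring carbon. Compound 1 `COc1cc(N2C(N)=C(C#N)C(c3cccc([N+](=O)[O-])c3)C3=C2CC(C)(C)CC3=O)cc(OC)c1OC` carries a 3-nitrophenyl there, compound 2 `COc1cc(N2C(N)=C(C#N)C(c3ccc(C)cc3)C3=C2CC(C)(C)CC3=O)cc(OC)c1OC` a 4-methylphenyl, and compound 3 `COc1ccc(C2C(C#N)=C(N)N(c3cc(OC)c(OC)c(OC)c3)C3=C2C(=O)CC(C)(C)C3)cc1` a 4-methoxyphenyl. In a functional assay on Ehrlich cells (Mus musculus) for cytotoxicity, tested at 50 ug/mL (on this read-out higher numbers stand for a stronger effect at the one concentration tested and lower numbers for a weaker effect), compound 1 gives 30%, compound 2 gives 60%, and compound 3 gives 11%. Compound 3 thus stands lowest of the three: the step of a number 19 percentage points lower from compound 1 to compound 3 (beyond the scatter) and the step of a number 49 percentage points lower from compound 2 to compound 3 (beyond the scatter) both run downward to it, and both lie beyond the scatter.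

Compound 4 `COc1cc(N2C(N)=C(C#N)C(c3ccccc3)C3=C2CC(C)(C)CC3=O)cc(OC)c1OC` is the next member. The change from compound 3 to compound 4 is hydrogen in place of methoxy on an aromatic carbon. Among the measured compounds shown here, no measured pair shows exactly this change. The nearest guide is a number 49 percentage points lower from compound 2 to compound 3 (beyond the scatter), where a methoxy on the aromatic carbon, in place of methyl, went with the largest drop in the set; a number 19 percentage points lower from compound 1 to compound 3 (beyond the scatter) also ends at compound 3 as the lowest number. Taking the methoxy away is therefore expected to move the number upward by a modest amount, though where a plain phenyl lands is uncertain. Compound 4 is estimated at 35%, within 15% to 60%, an expected step of a number 24 percentage points higher from compound 3 to compound 4 (beyond the scatter).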

Compound 4, a percentage reported as activity, at one concentration (the size of the read-out at that concentration, not a potency): 8%
For compound 4 the middle estimate is 27 percentage points above the measured one; measured number outside the range, below it.
By their numbers in this assay, from the lowest: compounds 4 and 3 (each within the scatter of the next); then compound 1; then compound 2.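

In this assay, taking the methoxy off changes nothing that can be told apart from scatter (a number 3 percentage points lower from compound 3 to compound 4 (within the scatter)), so the low number of compound 3 cannot be pinned on the methoxy as a group that pulls the read-out down. The plain phenyl now gives this position a baseline, and against it two groups stand out: the comparison with the 4-methylphenyl reads a number 52 percentage points lower from compound 2 to compound 4 (beyond the scatter) and the one with the 3-nitrophenyl reads a number 22 percentage points lower from compound 1 to compound 4 (beyond the scatter), so at this position the methyl and the nitro go with higher numbers than hydrogen, while the methoxy, in compound 3, goes against that pattern. The data at hand offer no measurement that would explain this difference among the groups.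

Still open, going by these compounds, is whether other groups in the para place would rise above the plain phenyl as the methyl does, for example an amine, a carboxylic acid or a longer chain such as ethyl. Also open, on these data alone, is whether the nitro would give a similar number in that same para place, and whether this order of compounds would hold across several concentrations.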